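Trimming the Chain End: Methoxy to Methyl

This account rests on a few compounds, and the source may have more. Where it says the series, first, only, none or still open, it means among the compounds named here.

Compound 1 `CNC(=O)C[C@@H]1C[C@@H](c2ccc(F)c(F)c2)[C@H](NC(=O)c2cc(-c3c(Cl)cnn3C)c(Cl)o2)CN1`: 800 nM
Compound 2 `COCC[C@@H]1C[C@@H](c2ccc(Cl)c(Cl)c2)[C@H](NC(=O)c2cc(-c3c(Cl)cnn3C)c(Cl)o2)CN1`: 1060 nM
Compound 3 `Cn1ncc(Cl)c1-c1cc(C(=O)N[C@@H]2CN[C@H](CCNS(C)(=O)=O)C[C@H]2c2ccc(F)c(F)c2)oc1Cl`: 1530 nM

Three compounds sharing one core were tested in a functional assay on OVCAR-8 cells (Homo sapiens) for antiproliferative activity; a lower number here means a stronger inhibitor, a higher number a weaker inhibitor. Compound 2 gives 1060 nM, a number that lies within the usual scatter of both compound 1 and compound 3, so no ranking among the three can be claimed. Compound 4 `CCC[C@@H]1C[C@@H](c2ccc(Cl)c(Cl)c2)[C@H](NC(=O)c2cc(-c3c(Cl)cnn3C)c(Cl)o2)CN1` has not yet been measured. It differs from compound 2 at the chain: methyl in place of methoxy on a saturated chain carbon, two bonds along the chain from a saturated ring carbon. Among the measured compounds shown here, the only measured step also alters a chain end, and it moved little: a 1.9-fold higher number from compound 1 to compound 3 (0.28 log units; within the scatter). It swaps a different group, so it does not bear directly on this change; it only shows that the chain end tolerates alteration. Relative to compound 2, the expected step for compound 4 is a 1.1-fold higher number from compound 2 to compound 4 (0.05 log units; within the scatter), nothing beyond the scatter. Compound 4 is estimated at 1200 nM, with a range from 500 nM to 3000 nM.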

Compound 4, half-maximal inhibitory concentration: 1620 nM
Estimate against measurement, compound 4: 1.4-fold (0.13 log units) below, and the stated range covers the measured number.
By their numbers in this assay, from the lowest: compounds 1, 2, 3 and 4 (each within the scatter of the next, the first and the last beyond it).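

Methyl in place of methoxy on this chain gives a 1.5-fold higher number from compound 2 to compound 4 (0.18 log units; within the scatter) in this assay, the first direct reading of this change. The 2-methoxyethyl and propyl chains therefore cannot be told apart here, so the loss of the chain oxygen, with its one hydrogen-bond acceptor, shows no effect beyond the scatter. No supporting measurement bears on this result. Still open, on these data alone, is whether an amine or a carboxylic acid at the chain end, or a longer chain such as butyl, would shift the number beyond the scatter.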